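A few compounds are considered here, and "the series" means these few. Any claim that something is new, unique, unknown or untested is made for them only; others in the source may bear on it.

Measured so far in a functional assay on A549 cells (Homo sapiens), read by MTT assay, with a stated time of 72 h; a lower number here means a stronger inhibitor, a higher number a weaker inhibitor:
Compound 1 `O=c1[nH]cnc2c1c(-c1ccoc1)cn2[C@@H]1O[C@H](CO)[C@@H](O)[C@H]1O` gives > 20000 nM, a limit of the assay.
Compound 2 `CN(C)c1ncnc2c1c(-c1ccsc1)cn2[C@@H]1O[C@H](CO)[C@@H](O)[C@H]1O` gives > 20000 nM, also a limit.
Compound 3 `CN(C)c1ncnc2c1c(-c1ccoc1)cn2[C@@H]1O[C@H](CO)[C@@H](O)[C@H]1O` gives > 20000 nM, again a limit.

Compound 1 thus stands only at a limit in this assay, as do the two other values shown. Among the compounds with values here, the single measured step, a step that the two limits leave unreadable from compound 2 to compound 3, runs between two limits, so its size cannot be read and it shows no direction. Compound 4 `O=c1[nH]cnc2c1c(-c1cccs1)cn2[C@@H]1O[C@H](CO)[C@@H](O)[C@H]1O` differs from compound 1 by thiophen-2-yl in place of furan-3-yl on an aromatic carbon. Since every value sits at the limit (the limit of > 20000 nM in this assay, at which 3 of the 3 values shown sit), no step beyond the scatter can be expected in this assay either way, and compound 4 is expected to stay at that limit. The estimate for compound 4 is 30000 nM, within 10000 nM to 100000 nM, an expected step that the limit leaves unreadable from compound 1 to compound 4.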

Compound 4, half-maximal inhibitory concentration: > 20000 nM
Compound 4: a limit, no number; the forecaster's own chance of this, stated with the estimate: 85%; the middle value does not contradict the limit.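

In this assay compound 4 gives > 20000 nM, a limit, and compound 1 stands at a limit too, so no step can be read between compound 1 and compound 4. The compounds shown leave open how their strengths compare, as none gives a number: the limit of > 20000 nM in this assay, at which 4 of the 4 values shown sit.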